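This account rests on a few compounds, and the source may have more. Where it says the series, first, only, none or still open, it means among the compounds named here.

Compound 1 `Oc1cc(-c2ccc(Cl)cc2)nc2ncccc12` and compound 2 `Cc1cnc2nc(-c3ccc(Cl)cc3)cc(O)c2c1` share a core and differ in one place: methyl in place of hydrogen on an aromatic carbon. In a functional assay on NCI-H460 cells (Homo sapiens) (a higher number here means a weaker inhibitor of growth, a lower number a stronger inhibitor of growth), compound 1 gives 38000 nM, while compound 2 gives 3890 nM, so that single change made a 9.8-fold lower number from compound 1 to compound 2 (0.99 log units; beyond the scatter). Compound 3 `COc1ccccc1-c1cc(O)c2cccnc2n1` carries a different group on the same kind of core; the difference between the two cores is not broken down here. In this assay compound 3 gives 38900 nM, which sits within the scatter of compound 1 and is about as far from compound 2 as compound 1 is.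

Compound 4 `COc1ccccc1-c1cc(O)c2cc(C)cnc2n1` is related to compound 3 in the same way that compound 2 is related to compound 1: methyl in place of hydrogen on an aromatic carbon. The place of the change is described in the same words for both pairs, so the change is the same. Only one example of it has been measured, and whether it carries over to the core of compound 3 is not shown by anything else here. Because a 9.8-fold lower number from compound 1 to compound 2 (0.99 log units; beyond the scatter) was clearly beyond the scatter, a step of similar direction is expected for compound 4, though with a wide margin for a single precedent.

In this assay compound 4 is expected to give 5000 nM, which means an expected 7.8-fold lower number from compound 3 to compound 4 (0.89 log units; beyond the scatter), with a likely range from 2000 nM to 15000 nM.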

Compound 4, concentration for 50% growth inhibition: 32400 nM
For compound 4 the middle estimate is 6.5-fold (0.81 log units) below the measured one; measured number above the stated range.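

In this assay, within the data shown here, on the core of compound 3, methyl in place of hydrogen gives a 1.2-fold lower number from compound 3 to compound 4 (0.08 log units; within the scatter), so on this core the step cannot be told apart from no step at all. Set beside the earlier pair, the same change does not have the same size on the two cores: the same change on two cores in this assay, a 9.8-fold lower number (0.99 log units; beyond the scatter) from compound 1 to compound 2 and a 1.2-fold lower number (0.08 log units; within the scatter) from compound 3 to compound 4, 8.1-fold (0.91 log units) apart, beyond the scatter of two such steps

Within this small set, then, the step seen on the core of compound 1 proved a poor guide to the step on the core of compound 3, but with only one pair per core the data do not show why the two steps differ, nor what the methyl would do on any further core.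

The compounds shown leave open whether the large step from compound 1 to compound 2 depends on the group that sets the two cores apart, which pairs with other groups in that spot could test. They also leave open whether another group on the same aromatic carbon, such as an ethyl, a fluorine or an amine, would behave differently on the two cores.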